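The source may hold more compounds than are shown below. What is called first, only, known or untested is meant among the compounds shown, and "the series" means these compounds.

Measured in a functional assay on K562 cells (Homo sapiens) for antiproliferative activity, read by MTT assay, with a stated time of 48 h; a higher number here means a weaker inhibitor, a lower number a stronger inhibitor:
Compound 1 `Cc1nc2ccc(Cl)cc2nc1Oc1ccc(C(=O)N[C@@H](CC(C)C)C(=O)O)cc1`: 14500 nM
Compound 2 `COC(=O)CNC(=O)c1ccc(Oc2nc3ccccc3nc2NC(C)(C)C)cc1`: > 50000 nM (a limit)

Compound 2 has no number of its own. It stands at the limit of > 50000 nM in this assay, at which 1 of the 2 values shown sits. Compound 3 `CC(C)(C)Nc1nc2ccccc2nc1Oc1ccc(C(=O)NCC(=O)O)cc1` departs from compound 2 in one place, hydrogen in place of methyl on an oxygen next to a carbonyl group, which turns methoxycarbonyl into carboxy. Going by the values given here, no step between measured compounds gauges this change, and compound 1 differs from compound 2 in more than one place. Still, compound 1, which also carries a carboxy group, gives 14500 nM, so a carboxy group does not by itself rule out a measurable value in this assay. On that single comparison, a modest shift towards stronger inhibition is expected, and it may well stay hidden behind the limit. The expected size of the change is an at least 1.2-fold lower number from compound 2 to compound 3 (0.09 log units; that floor lies within the scatter). Compound 3 is estimated at 40000 nM, with an expected range of 15000 nM to 80000 nM.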

Compound 3, half-maximal inhibitory concentration: > 50000 nM
Compound 3: only a limit was reported; the forecaster's own chance of this, stated with the estimate: 50%; at least 1.2-fold (0.09 log units) between middle value and limit.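

Compound 2 and compound 3 each stand at a limit rather than at a number in this assay, so the step between them cannot be read: the limit of > 50000 nM in this assay, at which 2 of the 3 values shown sit.

The compounds shown leave open whether turning methoxycarbonyl into carboxy changes the result in this assay at all, and, if it does, in which direction and by how much.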